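Two methoxy placements on the anilino ring in A-431 cells

The compounds below may be only part of what the source reports. "The series", "measured", "known", "first", "only" and "open" are said of these compounds alone.

Compound 1 `COc1ccc(Nc2n[nH]c(-c3cccnc3Nc3cc(OC)cc(OC)c3)n2)cc1` and compound 3 `COc1cccc(Nc2n[nH]c(-c3cccnc3Oc3cc(OC)cc(OC)c3)n2)c1` share much of their structure, but the difference between the two cores is not broken down here. In a functional assay on A-431 cells (Homo sapiens), tested at 0.1 uM (a higher number here means more inhibition at the concentration tested (going by the name of the read-out), a lower number less inhibition), compound 1 gives 68%, while compound 3 gives 83%. Compound 2 `COc1cc(Nc2ncccc2-c2nc(Nc3ccc(OC)cc3OC)n[nH]2)cc(OC)c1` carries one change relative to compound 1, (methoxy in place of hydrogen on an aromatic carbon), and in this assay compound 2 gives 17%, a step of a number 51 percentage points lower from compound 1 to compound 2 (beyond the scatter). Compound 4 `COc1cc(Nc2n[nH]c(-c3cccnc3Oc3cc(OC)cc(OC)c3)n2)cc(OC)c1` has not been measured. It differs from compound 3 by methoxy in place of hydrogen on an aromatic carbon, the same kind of change, though the entering methoxy here sits meta to a large group rather than ortho to it. Among the compounds with values here, because the one measured example of this change, a number 51 percentage points lower from compound 1 to compound 2 (beyond the scatter), was a large drop, some loss is expected for compound 4, but with the placement differing its size is uncertain, and an estimated step of a number 23 percentage points lower from compound 3 to compound 4 (beyond the scatter) is taken. Compound 4 is therefore expected to give about 60% in this assay, within a range of 25% to 88%.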

Compound 4, a percentage reported as inhibition, at one concentration (the size of the read-out at that concentration, not a potency): 87%
The estimate for compound 4 lay 27 percentage points below the measured number, within the range that was stated.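

In this assay the added methoxy gives a number 4 percentage points higher from compound 3 to compound 4 (within the scatter) and so leaves the read-out on the core of compound 3 without a change that can be told from scatter. The large drop seen on the core of compound 1 therefore did not carry over to the core of compound 3, and the two outcomes differ clearly: the same change on two cores in this assay, a number 51 percentage points lower (beyond the scatter) from compound 1 to compound 2 and a number 4 percentage points higher (within the scatter) from compound 3 to compound 4, 55 percentage points apart, beyond the scatter of two such steps. This shows that, in this series, the effect of this change on one core cannot simply be read across to the other, but with a single pair per core it does not show whether the difference between the cores or the different place of the entering methoxy accounts for the gap.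

The compounds shown leave open which of these two matters, as no pair holds the core fixed while moving the methoxy. They also leave open how a group such as an amine or a carboxylic acid, entering in place of the methoxy, would read on either core.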